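A few compounds are considered here, and "the series" means these few. Any claim that something is new, unique, unknown or untested is made for them only; others in the source may bear on it.

Compound 3 `c1coc(-c2ccccc2OCC2=NCCN2)c1` gives 110% in a functional assay for activation of Alpha-1B adrenergic receptor (Homo sapiens), read by calcium flux; a lower number here means a smaller maximal response, a higher number a larger maximal response. Among the three measured compounds it stands second highest: compound 1 `c1cncc(-c2ccccc2OCC2=NCCN2)c1` at 111% lies within the scatter of it, while compound 2 `c1ccc(-c2cnccn2)c(OCC2=NCCN2)c1` at 46% lies far lower. Compound 4 `c1c[nH]c(-c2ccccc2OCC2=NCCN2)c1` differs from compound 3 in one place: 1H-pyrrol-2-yl in place of furan-2-yl on an aromatic carbon. Going by the values given here, two measured steps bear on this exchange of the ring. The step of a number 1 percentage points lower from compound 1 to compound 3 (within the scatter) shows pyridin-3-yl and furan-2-yl giving the same response, whereas a number 64 percentage points higher from compound 2 to compound 3 (beyond the scatter) shows pyrazin-2-yl giving a much smaller one. Since 1H-pyrrol-2-yl, like furan-2-yl, is a five-membered aromatic ring with one hetero atom, a change within the scatter is expected, a number 10 percentage points lower from compound 3 to compound 4 (within the scatter). Compound 4 is therefore estimated at 100%, between 60% and 120%.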

Compound 4, largest response reached (reported as maximum), in percent of the reference or control that the assay uses: 104%
Compound 4: the middle estimate sits 4 percentage points below what was measured, within the range that was stated.
By their numbers in this assay, from the lowest: compound 2; then compounds 4, 3 and 1 (each within the scatter of the next).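

With 1H-pyrrol-2-yl in place of furan-2-yl, a hydrogen-bond donor replaces a hydrogen-bond acceptor, yet this assay does not separate the two rings (a number 6 percentage points lower from compound 3 to compound 4 (within the scatter)). Compound 4 also matches the pyridin-3-yl ring (a number 7 percentage points lower from compound 1 to compound 4 (within the scatter)), while the pyrazin-2-yl ring stays well apart (a number 58 percentage points higher from compound 2 to compound 4 (beyond the scatter)), so compound 2 alone among these four gives a much smaller response. No measurement here accounts for these results. Still open, as far as these compounds go, is how thiophen-2-yl, with sulfur as its hetero atom, or a plain phenyl ring would respond on this aromatic carbon.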